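Thiosemicarbazide series: morpholine to thiomorpholine on compound 2

The compounds below may be only part of what the source reports. "The series", "measured", "known", "first", "only" and "open" are said of these compounds alone.

Two compounds of this series have numbers in a functional assay on MCF7 cells (Homo sapiens) for cytotoxicity, read by MTT assay, with a stated time of 72 h, tested at 30 uM (a lower number here means less inhibition of growth, a higher number more inhibition of growth at the concentration tested), so far. Compound 1 `N/C(=N\NC(=S)N1CCOCC1)c1ccccn1` gives 78.1% in this assay. Among the measured compounds shown here, compound 2 `Cc1ccnc(/C(N)=N/NC(=S)N2CCOCC2)c1` gives 8.16% in this assay, the lowest of the two numbers; the only step to it, a number 69.9 percentage points lower from compound 1 to compound 2 (beyond the scatter), is a methyl in place of hydrogen on an aromatic carbon and is large.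

Compound 3 `Cc1ccnc(/C(N)=N/NC(=S)N2CCSCC2)c1` is not yet measured. It differs from compound 2 by thiomorpholin-4-yl in place of morpholin-4-yl on a thiocarbonyl carbon. For the measured compounds named here, no measured step touches the group on the thiocarbonyl carbon: the single step known, from compound 1 to compound 2, alters the aromatic ring and says nothing about an exchange of morpholin-4-yl for thiomorpholin-4-yl. The expectation therefore rests on compound 2 alone, and the step from compound 2 to compound 3 is expected to be a number 3.8 percentage points higher from compound 2 to compound 3 (within the scatter), not beyond the scatter in either direction, with a wide range owing to the absence of any bearing step.

Compound 3 is thus estimated at 12% in this assay, between 0% and 40%.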

Compound 3, percent growth inhibition at one concentration: 74.2%
Estimate against measurement, compound 3: 62.2 percentage points below; the whole stated range lies below it.
By their numbers in this assay, from the lowest: compound 2; then compounds 3 and 1 (each within the scatter of the next).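

In this assay, among the compounds shown here, the first measured exchange on the thiocarbonyl carbon, thiomorpholin-4-yl in place of morpholin-4-yl, gives a number 66 percentage points higher from compound 2 to compound 3 (beyond the scatter) and shows that this position strongly affects the read-out. The two groups have the same counts of heavy atoms, hydrogen-bond donors and hydrogen-bond acceptors, and they differ by sulfur in place of oxygen in the ring, so a single ring atom is enough for a large step here. The earlier step, a number 69.9 percentage points lower from compound 1 to compound 2 (beyond the scatter) for methyl in place of hydrogen on an aromatic carbon, might have suggested that the methyl compounds were poor as a class, but compound 3 carries the same methyl and gives 74.2% as the number for this pair.

No available measurement explains the step from oxygen to sulfur. Still open, on these data alone, is how the thiocarbonyl position responds to other rings such as piperidin-1-yl or 4-methylpiperazin-1-yl, and what thiomorpholin-4-yl does on the core of compound 1 without the methyl.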